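Pyrazole acids on renal cells: a halogen swap

The source may report more compounds than this note shows. Statements on the series, on what has been measured and on what is new or still open speak of the compounds shown alone.

Measured so far in a functional assay on 786-0 cells (Homo sapiens) for inhibition, read by sulforhodamine B assay, with a stated time of 48 h; a higher number here means a weaker inhibitor of growth, a lower number a stronger inhibitor of growth:
compound 1, `CC(C)(C)NCc1c(C(=O)O)nn(-c2ccccc2)c1-c1ccc(F)cc1`: > 680000 nM, a limit of the assay.
compound 2, `CC(C)(C)NCc1c(C(=O)O)nn(-c2ccccc2)c1-c1ccc(Cl)cc1`: > 652000 nM, a limit of the assay.
compound 3, `CC(C)(C)NCc1c(C(=O)O)nn(-c2ccc(Cl)cc2)c1-c1ccc(F)cc1`: 204000 nM.

Compound 2 differs from compound 1 by chloro in place of fluoro on an aromatic carbon. The step that the two limits leave unreadable from compound 1 to compound 2. Compound 1 sits at the limit of > 680000 nM in this assay, at which 1 of the 3 values shown sits. Compound 2 sits at the limit of > 652000 nM in this assay, at which 1 of the 3 values shown sits.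

Compound 3 differs from compound 1 by chloro in place of hydrogen on an aromatic carbon; this is also how the two cores differ. Within the data shown here, it is the only number among the three. The step of an at least 3.3-fold lower number from compound 1 to compound 3 (0.52 log units; beyond the scatter).

Compound 4, `CC(C)(C)NCc1c(C(=O)O)nn(-c2ccc(Cl)cc2)c1-c1ccc(Cl)cc1`, is not yet measured. It differs from compound 3 by chloro in place of fluoro on an aromatic carbon, the same change as from compound 1 to compound 2, whose size the two limits leave unreadable. A step of a 1.0-fold lower number from compound 3 to compound 4 (0.01 log units; within the scatter) is expected, resting on the value of compound 3, 204000 nM, with the earlier instance of the change giving no readable size. Compound 4 is estimated at 200000 nM in this assay.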

Compound 4, concentration for 50% growth inhibition: > 599000 nM
Compound 4 was reported as a limit (the forecaster's own chance of this, stated with the estimate: 20%); at least 2.9-fold (0.47 log units) between middle value and limit.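

In this assay, 4-fluorophenyl to 4-chlorophenyl on the core of compound 3 gives an at least 2.9-fold higher number from compound 3 to compound 4 (0.46 log units; beyond the scatter). Compound 4 stands at > 599000 nM, a limit of the assay. The steps from compound 1 to compound 2 and from compound 2 to compound 4 cannot be read, so the change has a readable size on one core only, and nothing shows whether that size carries over to the core of compound 1.

Open, going by these compounds, is whether a methoxy or nitrile in place of the fluoro of compound 3 would give a readable number. Also open, on these data alone, is how a methyl ester or an amide in place of the carboxylic acid would read.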